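Alkyl in place of aryl beside the amine

The source may hold more compounds than are shown below. What is called first, only, known or untested is meant among the compounds shown, and "the series" means these compounds.

Going by the values given here, compound 3 `Nc1cc(-c2ccccc2)nc2ccc(NC(=O)/C=C/c3ccc(C(F)(F)F)cc3)cc12` stands at the top of the three numbers so far: in a functional assay on HEK293 cells for activation of melanin-concentrating hormone receptor 1 (Homo sapiens), read by inositol phosphate accumulation (a higher number here means that more compound is needed for the effect, a lower number that less compound is needed), compound 3 gives 6600 nM, against compound 2 `CCCc1cc(N2CCCC2)c2cc(NC(=O)/C=C/c3ccc(C(F)(F)F)cc3)ccc2n1` with 2800 nM and compound 1 `CCCc1cc(NC)c2cc(NC(=O)/C=C/c3ccc(C(F)(F)F)cc3)ccc2n1` with 150 nM. Among the compounds with values here, the only measured step, a 19-fold higher number from compound 1 to compound 2 (1.27 log units; beyond the scatter), concerns the amino group and does not bear on the change considered here. Compound 4 `CCC(C)c1cc(N)c2cc(NC(=O)/C=C/c3ccc(C(F)(F)F)cc3)ccc2n1` differs from compound 3 by sec-butyl in place of phenyl on an aromatic carbon. Within the data shown here, no measured pair isolates this change; the nearest guide is that compounds 1 and 2, both carrying an alkyl chain rather than a phenyl, sit at lower numbers than compound 3, while their amino groups also differ from the primary amine shared by compounds 3 and 4, so the comparison is loose. A step in the downward direction, beyond the scatter, is therefore expected for compound 4, estimated at a 13-fold lower number from compound 3 to compound 4 (1.12 log units; beyond the scatter). In this assay compound 4 is expected at 500 nM, with a range from 100 nM to 2500 nM.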

Compound 4, half-maximal effective concentration: 44 nM
Compound 4: the middle estimate sits 11-fold (1.06 log units) above what was measured; measured number below the stated range.
By their numbers in this assay, from the lowest: compound 4; then compound 1; then compound 2; then compound 3.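

With the primary amine held constant, sec-butyl in place of phenyl on the aromatic carbon next to the ring nitrogen gives a 150-fold lower number from compound 3 to compound 4 (2.18 log units; beyond the scatter) in this assay. Going by these compounds alone, this pair is the first to isolate the change at this position, which the looser comparison of compound 3 with compound 1 and compound 2 could not do. In this pair, a chain of 4 heavy atoms in place of the aromatic ring of 6 carbons goes with a far lower number, and nothing on hand accounts for the size of the step.

As far as these compounds go, whether this step follows from the branching or from the loss of the aromatic ring remains open; an n-butyl chain and a cyclohexyl ring at this position would separate the two. Also open, from the compounds shown here alone, is whether the step persists with methylamino or pyrrolidin-1-yl in place of the primary amine.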